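Taking the acyl group off compound 2

This account rests on a few compounds, and the source may have more. Where it says the series, first, only, none or still open, it means among the compounds named here.

Compound 1 `CCCCOC(=O)CNC(=O)[C@H](CSc1ccc([N+](=O)[O-])cc1[N+](=O)[O-])NC(=O)CC[C@H](NC(=O)OCc1ccccc1)C(=O)OCCCC` and compound 2 `CCCCOC(=O)CNC(=O)[C@H](CSc1ccc([N+](=O)[O-])cc1[N+](=O)[O-])NC(=O)CC[C@H](NC(=O)C(C)C)C(=O)OCCCC` share one core and differ only in a single group on a carbonyl carbon. In a toxicity assay on KB cells (Homo sapiens) for cytotoxicity, read by fluorescence, with a stated time of 3 days (on this read-out higher numbers stand for an effect only at larger amounts of compound and lower numbers for an effect already at smaller amounts), compound 1 gives 95.2 uM as its half-maximal concentration. Compound 2 gives > 300 uM as a reading, and this is a limit of the assay and not a number. Compound 2 therefore has no exact place on the scale.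

Compound 3 `CCCCOC(=O)CNC(=O)[C@H](CSc1ccc([N+](=O)[O-])cc1[N+](=O)[O-])NC(=O)CC[C@H](N)C(=O)OCCCC` comes from compound 2 by a single change, hydrogen in place of isopropylcarbonyl on an amine nitrogen. Within the data shown here, only one measured step bears on this: an at least 3.1-fold higher number from compound 1 to compound 2 (0.49 log units; beyond the scatter) is a change in the group on that same carbonyl, and it lies beyond the scatter. Among the measured compounds shown here, that step shows that this part of the molecule can move the reading in this assay, but no measured compound has lost the carbonyl group altogether, so the size stays uncertain. The expected direction is towards a lower number, and the estimate is an at least 7.5-fold lower number from compound 2 to compound 3 (0.87 log units; beyond the scatter) as a rough guide. Compound 3 is expected at about 40 uM on this read-out, with an estimated range from 10 uM to 200 uM for repeated measurements.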

Compound 3, concentration for half-maximal effect: 107 uM
The estimate for compound 3 lay 2.7-fold (0.43 log units) below the measured number; measured number inside the range.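

In this assay, the bare amine of compound 3 cannot be told apart from the benzyloxycarbonyl-capped amine of compound 1: a 1.1-fold higher number from compound 1 to compound 3 (0.05 log units; within the scatter). Taking off the isopropylcarbonyl group, by contrast, gives an at least 2.8-fold lower number from compound 2 to compound 3 (0.44 log units; beyond the scatter), so a carbonyl cap on this amine nitrogen does not by itself push the number up, and compound 1 is the case that goes against any such rule. Compound 2 stands out from the other two with this one cap, yet its reading is a limit of the assay and not a number, so that step has only a minimum size and no exact one: the limit of > 300 uM in this assay, at which 1 of the 3 values shown sits.

The compounds shown do not tell whether it is the isopropylcarbonyl group in particular that sets compound 2 apart, or whether an acetyl group, a benzoyl group or a longer chain on the same carbonyl would read like it or like the benzyloxycarbonyl group. They also leave open whether the same picture would hold with carboxylic acids in place of the butyl esters.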